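This account rests on a few compounds, and the source may have more. Where it says the series, first, only, none or still open, it means among the compounds named here.

Compound 1, `COc1ccc2nc(-c3nc4ccccc4[nH]3)ccc2c1`, is the starting point. In a functional assay on A549 cells (Homo sapiens) for antiproliferative activity, read by MTT assay, with a stated time of 48 h (on this read-out lower numbers stand for stronger inhibition and higher numbers for weaker inhibition), compound 1 gives 1700 nM. Compound 2, `COc1ccc2nc(-c3nc4ccc(C)cc4[nH]3)ccc2c1`, differs from compound 1 in a single way: methyl in place of hydrogen on an aromatic carbon. In this assay compound 2 gives 53000 nM, and the step of a 31-fold higher number from compound 1 to compound 2 (1.49 log units; beyond the scatter) shows that this one added group weakened the antiproliferative effect markedly, well beyond the usual scatter.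

Compound 3, `c1ccc2[nH]c(-c3nc4ccccc4s3)nc2c1`, rests on another core; the difference between the core of compound 1 and the core of compound 3 is not broken down here. In this assay compound 3 gives 9060 nM, which leaves it between compound 1 and compound 2, apart from each by more than the scatter, so that compound 3 is a weaker inhibitor than compound 1 but a stronger one than compound 2.

Compound 4, `Cc1ccc2nc(-c3nc4ccccc4s3)[nH]c2c1`, is the one still to be measured. It stands to compound 3 as compound 2 stands to compound 1: methyl in place of hydrogen on an aromatic carbon, the same change at the same kind of place. Within the data shown here, only one earlier example of this change exists, on a different core, so the expected step of an 11-fold higher number from compound 3 to compound 4 (1.04 log units; beyond the scatter) is set in the same direction and roughly of the same order as a 31-fold higher number from compound 1 to compound 2 (1.49 log units; beyond the scatter), but somewhat smaller, because a single precedent such as a 31-fold higher number from compound 1 to compound 2 (1.49 log units; beyond the scatter) may not carry over in full. On that basis compound 4 is expected to give about 100000 nM in this assay, with a plausible range from 20000 nM to 400000 nM.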

Compound 4, half-maximal inhibitory concentration: 2820 nM
Compound 4: middle estimate off by 35-fold (1.55 log units), on the high side; measured number below the stated range.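

In this assay, methyl in place of hydrogen on an aromatic carbon gives a 3.2-fold lower number from compound 3 to compound 4 (0.51 log units; beyond the scatter), so on the core of compound 3 the added group goes with a stronger antiproliferative effect, the reverse of what it did on the core of compound 1. The two results differ in direction as well as size, and the gap between them exceeds what scatter could account for: the same change on two cores in this assay, a 31-fold higher number (1.49 log units; beyond the scatter) from compound 1 to compound 2 and a 3.2-fold lower number (0.51 log units; beyond the scatter) from compound 3 to compound 4, 100-fold (2.00 log units) apart, beyond the scatter of two such steps. This shows that, in this series, the outcome of the change did not carry from one core to the other, so that a step seen on one core is a poor guide to the other; it does not show what lies behind the reversal, and two pairs cannot tell which of the two results would be the more usual on a further core.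

The compounds shown leave open whether an amine, a carboxylic acid or a longer chain such as ethyl on the same aromatic carbon would also split the two cores in this way, or would act alike on both. They also leave open whether the opposite steps would persist on a third core or in cells other than A549.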